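Amide aryl exchange on the shared core

The compounds below may be only part of what the source reports. "The series", "measured", "known", "first", "only" and "open" are said of these compounds alone.

Compound 1 `Cc1ccc(C(=O)Nc2cc(-c3ccccc3)nn2-c2ccccc2)cc1` gives 40 nM in an assay on isolated protein with metabotropic glutamate receptor 5 (Rattus norvegicus) as the target (a higher number here means that more compound is needed for the effect, a lower number that less compound is needed), the lowest number among the three measured compounds, with both neighbours beyond the scatter. Compound 2 `O=C(Nc1cc(-c2ccccc2)nn1-c1ccccc1)c1cccc(Cl)c1` gives 200 nM in this assay, and compound 3 `O=C(Nc1cc(-c2ccccc2)nn1-c1ccccc1)c1ccccc1` gives 300 nM; these two values lie within the scatter of each other (a 1.5-fold higher number from compound 2 to compound 3 (0.18 log units; within the scatter)).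

Compound 4 `O=C(Nc1cc(-c2ccccc2)nn1-c1ccccc1)c1cnccn1` awaits measurement in this assay. Against compound 1 the change is pyrazin-2-yl in place of 4-methylphenyl on a carbonyl carbon. Both measured steps that start from compound 1 bear on it. a 7.5-fold higher number from compound 1 to compound 3 (0.88 log units; beyond the scatter) shows what removal of the methyl alone does, a modest upward step, and a 5.0-fold higher number from compound 1 to compound 2 (0.70 log units; beyond the scatter) shows that another exchange of the aryl group on the carbonyl carbon also gives a modest upward step. The change to compound 4 removes the methyl and exchanges the ring as well. For compound 4 an upward step beyond the scatter is therefore expected, a 10-fold higher number from compound 1 to compound 4 (1.00 log units; beyond the scatter). Within the data shown here, none of the measured compounds carries pyrazin-2-yl on the carbonyl, so the range is kept wide. For compound 4 the estimate in this assay is 400 nM, with a range from 100 nM to 1500 nM.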

Compound 4, half-maximal effective concentration: 400 nM
Estimate against measurement, compound 4: no gap at the digits printed; low and high end bracket the measured number.
By their numbers in this assay, from the lowest: compound 1; then compounds 2, 3 and 4 (each within the scatter of the next).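

In this assay, the change to pyrazin-2-yl on the carbonyl carbon does not separate compound 4 from the carbon-only rings, with a 1.3-fold higher number from compound 3 to compound 4 (0.12 log units; within the scatter) and a 2.0-fold higher number from compound 2 to compound 4 (0.30 log units; within the scatter), both within the scatter. Compound 1 alone stands apart, with a 10-fold higher number from compound 1 to compound 4 (1.00 log units; beyond the scatter), so among these four compounds the phenyl, 3-chlorophenyl and pyrazin-2-yl groups form one level, and the 4-methylphenyl group gives the lowest number, now against a ring carrying hetero atoms as well as against carbon-only rings. No measured information accompanies this result that could explain why the 4-methylphenyl group stands apart.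

Still open, going by these compounds, is whether a longer chain such as ethyl or propyl, or a methoxy group, in place of the methyl of compound 1 would hold that lowest number, and whether a methyl group on the pyrazin-2-yl ring of compound 4 would bring the number down to that of compound 1. The shared core is also unchanged in all four compounds, so nothing here shows how an amine or a carboxylic acid on its phenyl groups would act in combination with the 4-methylphenyl amide.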